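Phenyl for (pyridin-2-yl)methyl on the hydroxyacyl side chain

The source may report more compounds than this note shows. Statements on the series, on what has been measured and on what is new or still open speak of the compounds shown alone.

Measured compounds:
compound 1 `O=C(NCc1cc(Cl)ccc1-n1cnnn1)[C@@H]1C[C@@H]2C[C@@H]2N1C(=O)[C@H](O)Cc1ccccn1` — 1000 nM
compound 2 `O=C(NCc1cc(Cl)ccc1-n1cnnn1)[C@@H]1CC=NN1C(=O)[C@H](O)C1CCCCC1` — 970 nM

Of the compounds shown here, two have been measured in a functional assay on a cell-free system (plasma, Homo sapiens), with a stated time of 3 min; a higher number here means a weaker inhibitor, a lower number a stronger inhibitor. Compound 1 gives 1000 nM, the highest of the two numbers, yet compound 2 at 970 nM lies within the usual scatter of it, so the two cannot be told apart. The two also differ in more than one place, so no single step can be read from them.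

Compound 3 `O=C(NCc1cc(Cl)ccc1-n1cnnn1)[C@@H]1C[C@@H]2C[C@@H]2N1C(=O)[C@H](O)c1ccccc1` departs from compound 1 by one change: phenyl in place of (pyridin-2-yl)methyl on a saturated chain carbon bound to a carbonyl carbon and an oxygen on a saturated carbon. Among the measured compounds shown here, no measured pair shows the effect of such a change here, so the expectation rests on the shared core alone, which has given values close to compound 1 in both cases. The step of a 1.4-fold lower number from compound 1 to compound 3 (0.15 log units; within the scatter) is expected to stay small, most likely within the scatter or a little toward a lower number. Compound 3 is accordingly estimated at 700 nM, with a range from 250 nM to 2500 nM.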

Compound 3, half-maximal inhibitory concentration: 620 nM
Beside the measured number, compound 3's estimate is 1.1-fold (0.05 log units) above it, and the stated range covers the measured number.
By their numbers in this assay, from the lowest: compounds 3, 2 and 1 (each within the scatter of the next).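

In this assay, phenyl in place of (pyridin-2-yl)methyl on the saturated chain carbon bound to a carbonyl carbon and an oxygen on a saturated carbon gives a 1.6-fold lower number from compound 1 to compound 3 (0.21 log units; within the scatter). Among the compounds shown here, this is the first comparison in one place on the shared core, and it shows that this position accepts a ring of carbon only, without the ring nitrogen and its hydrogen-bond acceptor, with no step beyond the scatter. No measurement is available that would give a reason for the size of this step.

The change alters the ring and removes the methyl link together, so the pair does not separate the two; benzyl or pyridin-2-yl at this position would do so. On these data alone, how an amine or a carboxylic acid on the phenyl would read in this assay also remains open.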